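The source may hold more compounds than are shown below. What is called first, only, known or untested is meant among the compounds shown, and "the series" means these compounds.

Notes on the hydroxamate sulfonamide series, three compounds measured so far in an assay on isolated protein for inhibition of bone morphogenetic protein 1 (Homo sapiens); a lower number here means a stronger inhibitor, a higher number a weaker inhibitor.

Compound 1 `COc1ccc(S(=O)(=O)N(Cc2cc(C(F)(F)F)cc(C(F)(F)F)c2)[C@H](C)C(=O)NO)cc1` gives 220 nM in this assay. Compound 2 `COc1ccc(S(=O)(=O)N(CCn2cccc2)[C@H](C)C(=O)NO)cc1` gives 170 nM. Compound 3 `COc1ccc(S(=O)(=O)N(Cc2ccccc2C(F)(F)F)[C@H](C)C(=O)NO)cc1` gives 6 nM. Compound 2 holds the second highest of the three numbers; its nearest neighbour is compound 1, and the two values lie within the scatter of each other, so no order between them is read. Compound 3 sits far lower than compound 2, beyond the scatter, so the group attached through the saturated chain carbon on the sulfonamide nitrogen clearly matters for this assay.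

Compound 4 `COc1ccc(S(=O)(=O)N(Cc2cccc(Br)c2)[C@H](C)C(=O)NO)cc1` has not yet been measured. Relative to compound 2 the change is 3-bromophenyl in place of (1H-pyrrol-1-yl)methyl on a saturated chain carbon bound to a sulfonamide nitrogen

For the measured compounds named here, no directly measured pair isolates this exact change. The numbers for compound 3 and compound 1 show that a benzyl-type group on that carbon can give either a low or a high value, so compound 4 is expected to fall between them. The step of a 4.3-fold lower number from compound 2 to compound 4 (0.63 log units; beyond the scatter) is expected to run toward a lower number and beyond the scatter. For compound 4 the estimate in this assay is 40 nM, with a range of 10 nM to 150 nM.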

Compound 4, half-maximal inhibitory concentration: 93 nM
Compound 4: the middle estimate sits 2.3-fold (0.37 log units) below what was measured; the measured number falls inside the stated range.
By their numbers in this assay, from the lowest: compound 3; then compounds 4, 2 and 1 (each within the scatter of the next, the first and the last beyond it).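

In this assay, the change from 2-(1H-pyrrol-1-yl)ethyl to 3-bromobenzyl gives a 1.8-fold lower number from compound 2 to compound 4 (0.26 log units; within the scatter), the first single-place step read on the saturated chain carbon bound to the sulfonamide nitrogen, and it does not separate the two compounds even though the five-membered aromatic ring with its hydrogen-bond acceptor gives way to a six-membered aromatic ring of carbon only, carrying bromine. A benzyl-type group does not by itself bring the low number here, as compound 4 at 93 nM remains well above compound 3 at 6 nM and so the choice of group on the benzyl ring, not the benzyl frame alone, goes with the gap between these two compounds. Nothing available explains why the step from the pyrrole group to the bromine-bearing group is this small.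

A plain benzyl group with no ring substituent would show what the bromine of compound 4 and the trifluoromethyl of compound 3 each contribute against a common reference. On these data alone, a benzyl group carrying an amine or a carboxylic acid, and a longer chain ending in a phenyl ring, remain open at this position, so the reach of the series beyond these neutral groups cannot be judged.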